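The compounds below may be only part of what the source reports. "The series", "measured", "known", "first", "only" and "open" are said of these compounds alone.

In a functional assay on DU-145 cells (Homo sapiens) for cytotoxicity, read by MTT assay, with a stated time of 72 h (a lower number here means a stronger inhibitor, a higher number a weaker inhibitor), the series stands as follows:
- compound 1 `CCN(CC)c1cc2nc(-c3ccccc3)nn(-c3ccccc3)c-2cc1=O` with 3110 nM as a measured value
- compound 2 `CC(=O)Nc1cc2nc(-c3ccccc3)nn(-c3ccccc3)c-2cc1=O` with > 5000 nM as a limit, not a number
- compound 3 `COc1cc2nc(-c3ccccc3)nn(-c3ccccc3)c-2cc1=O` not yet measured

Compound 2 has no exact position and stands only at the limit of > 5000 nM in this assay, at which 1 of the 2 values shown sits, so any step from it is measured against a limit. The next change, from compound 2 to compound 3, is methoxy in place of acetamido on an aromatic carbon, counted as methoxy in place of acetamido on an aromatic carbon, with the rest of the shared core unchanged. For the measured compounds named here, only one measured step bears on it, an at least 1.6-fold higher number from compound 1 to compound 2 (0.20 log units; that floor lies within the scatter), where acetamido replaced diethylamino on an aromatic carbon. Going by the values given here, that step gives a floor and no full size, and no methoxy compound has yet been measured. Among the compounds with values here, the only number in this assay therefore anchors the expectation, and compound 3 is expected to lie near compound 1 (3110 nM). The estimated step is an at least 1.6-fold lower number from compound 2 to compound 3 (0.22 log units; that floor lies within the scatter), toward a lower number but not expected to go clearly beyond the scatter. Compound 3 is estimated at 3000 nM, with an expected range from 1000 nM to 9000 nM, and a result reported only as a limit remains possible.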

Compound 3, half-maximal inhibitory concentration: > 5000 nM
Compound 3: only a limit was reported; the forecaster's own chance of this, stated with the estimate: 35%; at least 1.6-fold (0.22 log units) between middle value and limit.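

In this assay compound 3 gives > 5000 nM, which is a limit and not a number, so a second, smaller group on this aromatic carbon, one without the hydrogen-bond donor of acetamido, also yields no exact value. Methoxy in place of diethylamino reads as an at least 1.6-fold higher number from compound 1 to compound 3 (0.20 log units; that floor lies within the scatter), so this change, like the one to acetamido, gives only a floor and does not separate the new compound from compound 1. The step from compound 2 to compound 3 cannot be read, and the position now rests mostly on a shared ceiling: the limit of > 5000 nM in this assay, at which 2 of the 3 values shown sit.

From the compounds shown here alone, whether acetamido and methoxy truly differ from diethylamino or from each other stays open, and with only compound 1 carrying a number, no trend across the groups at this position can be drawn. A free amine, a pyrrolidine ring or a longer alkoxy chain on the same carbon would show whether a measurable value belongs to tertiary amines generally or to diethylamino alone.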